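The source may report more compounds than this note shows. Statements on the series, on what has been measured and on what is new or still open speak of the compounds shown alone.

Measured compounds in a functional assay on OVCAR-3 cells (Homo sapiens) for inhibition, read by MTT assay, with a stated time of 24 h; on this read-out higher numbers stand for weaker inhibition and lower numbers for stronger inhibition:
compound 1 `Cc1ccccc1-n1cc(CN2C(=O)C[C@@H]3CC[C@@]2(C)C3(C)C)nn1`: 150 nM
compound 2 `COc1cccc(-n2cc(CN3C(=O)C[C@@H]4CC[C@@]3(C)C4(C)C)nn2)c1`: 280 nM
compound 3 `CC1(C)[C@H]2CC[C@]1(C)N(Cc1cn(-c3ccc(O)cc3)nn1)C(=O)C2`: 410 nM

Compound 1 gives the lowest number of the three in this assay. Its nearest neighbour is compound 2: the step of a 1.9-fold higher number from compound 1 to compound 2 (0.27 log units; within the scatter) lies within the scatter, so the two are not separated. The step of a 2.7-fold higher number from compound 1 to compound 3 (0.44 log units; beyond the scatter) is beyond the scatter, though modest. Between compound 2 and compound 3 the step of a 1.5-fold higher number from compound 2 to compound 3 (0.17 log units; within the scatter) is again within the scatter, so the three numbers span a narrow band with only compound 1 and compound 3 clearly apart.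

Compound 4 `Cc1cccc(-n2cc(CN3C(=O)C[C@@H]4CC[C@@]3(C)C4(C)C)nn2)c1` has not yet been measured in this assay. It differs from compound 1 in one place: 3-methylphenyl in place of 2-methylphenyl on an aromatic nitrogen. Among the measured compounds shown here, the closest precedent is the step of a 1.9-fold higher number from compound 1 to compound 2 (0.27 log units; within the scatter), where the same 2-methylphenyl was replaced by a 3-methoxyphenyl and the number stayed within the scatter. For the measured compounds named here, the only step beyond the scatter from compound 1, a 2.7-fold higher number from compound 1 to compound 3 (0.44 log units; beyond the scatter), was modest and brought in a hydroxyl, which compound 4 does not. A step of at most the size seen from compound 1 to compound 2 is therefore expected, upward in number if anything, and the estimate for compound 4 is 200 nM, between 100 nM and 450 nM, meaning an expected step of a 1.3-fold higher number from compound 1 to compound 4 (0.12 log units; within the scatter).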

Compound 4, half-maximal inhibitory concentration: 160 nM
Estimate against measurement, compound 4: 1.3-fold (0.10 log units) above; the range from low to high includes it.
By their numbers in this assay, from the lowest: compounds 1, 4, 2 and 3 (each within the scatter of the next, the first and the last beyond it).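

In this assay the methyl group can sit as in the 2-methylphenyl or as in the 3-methylphenyl on the aromatic nitrogen without separating the two compounds (a 1.1-fold higher number from compound 1 to compound 4 (0.03 log units; within the scatter)), so this shift of a single methyl leaves the read-out within the scatter. With the 3-substituted pair, methyl in place of methoxy also gives no separation (a 1.8-fold lower number from compound 2 to compound 4 (0.24 log units; within the scatter)), whereas 3-methylphenyl in place of 4-hydroxyphenyl gives a second modest step beyond the scatter (a 2.6-fold lower number from compound 3 to compound 4 (0.41 log units; beyond the scatter)), so compound 3 now stands clearly apart from both methylphenyl compounds, though not from compound 2. No measurement shown here gives a reason for any of these steps.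

Compound 3 changes both the group and its place on the ring relative to the methylphenyl compounds, so the series cannot say whether the hydroxyl or its place accounts for the higher number, and a 3-hydroxyphenyl or a 4-methylphenyl would separate the two. Also open, as far as these compounds go, is how this aryl position responds to a charged group such as an amine or a carboxylic acid on the phenyl ring, or to a longer chain in place of the methyl.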